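From 4-iodophenyl to 4-(dimethylamino)phenyl: cytotoxicity notes

A few compounds are considered here, and "the series" means these few. Any claim that something is new, unique, unknown or untested is made for them only; others in the source may bear on it.

In an ADME assay on L6 cells (Rattus norvegicus) for cytotoxicity, read by resazurin assay, with a stated time of 72 h (on this read-out lower numbers stand for stronger inhibition and higher numbers for weaker inhibition), compound 1 (`O=C1[C@H]2N=NN(Cc3nc(-c4ccc(F)cc4)no3)[C@H]2C(=O)N1c1ccccc1`) reads > 100 ug/mL, which is a limit of the assay and not a number. Among the measured compounds shown here, compound 2 (`O=C1[C@H]2N=NN(Cc3nc(-c4ccc(I)cc4)no3)[C@H]2C(=O)N1c1ccccc1`) gives 48.6 ug/mL, the only actual number so far. Compound 3 (`CN(C)c1ccc(-c2noc(CN3N=N[C@@H]4C(=O)N(c5ccccc5)C(=O)[C@@H]43)n2)cc1`) carries dimethylamino in place of iodo on an aromatic carbon. For the measured compounds named here, the one measured step bearing on this is an at least 2.0-fold lower number from compound 1 to compound 2 (0.31 log units; beyond the scatter), for iodo in place of fluoro, and its size is open-ended, with the limit of > 100 ug/mL in this assay, at which 1 of the 2 values shown sits. No step beyond the scatter is therefore expected, the estimated change being a 1.1-fold higher number from compound 2 to compound 3 (0.05 log units; within the scatter) in this assay. Compound 3 is estimated at 55 ug/mL (range 18 ug/mL to 130 ug/mL).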

Compound 3, half-maximal inhibitory concentration: > 100 ug/mL
Compound 3: only a limit was reported; the forecaster's own chance of this, stated with the estimate: 30%; middle value at least 1.8-fold (0.25 log units) away from the limit.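

Dimethylamino in place of iodo gives an at least 2.0-fold higher number from compound 2 to compound 3 (0.31 log units; beyond the scatter) in this assay, so of the three groups at this place on the aromatic ring, only iodo gives a measured number. Compound 3 gives > 100 ug/mL, which is a limit of the assay and not a number. The size of this step therefore stays open-ended, and the step from compound 1 to compound 3 cannot be read: the limit of > 100 ug/mL in this assay, at which 2 of the 3 values shown sit.

On these data alone, whether bromo, chloro, methyl or a carboxylic acid at this place would give a measured number like iodo remains open.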